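The compounds below may be only part of what the source reports. "The series", "measured", "known", "first", "only" and "open" are said of these compounds alone.

- compound 1 `Cc1ccc(NC(=O)CSc2nncnc2-c2cccc3ccccc23)c(Br)c1` gives 166000 nM
- compound 2 `Cc1cnc(NC(=O)CSc2nncnc2-c2ccccc2Cl)c(Br)c1` gives 144000 nM

Both numbers come from an ADME assay on MT4 cells (Homo sapiens) for cytotoxicity, read by MTT assay (a higher number here means that more compound is tolerated, a lower number that less compound is tolerated), and they lie within the usual scatter of each other, so compound 2 cannot be separated from compound 1 on these data.

Next in view is compound 3 `O=C(CSc1nncnc1-c1ccccc1Cl)Nc1ccccc1` with this change from compound 2: phenyl in place of 3-bromo-5-methylpyridin-2-yl on an amide-type nitrogen. Within the data shown here, no two measured compounds differ in only one place, so the series offers no direct measure of this exchange. Compound 1 at 166000 nM and compound 2 at 144000 nM stay within the scatter of each other even though their structures differ in more than one place. On that narrow basis, no step beyond the scatter is expected in this assay and neither direction is favoured. The estimated step of a 1.0-fold higher number from compound 2 to compound 3 (0.02 log units; within the scatter) is expected to remain within the scatter. For compound 3 the expected value is 150000 nM with an estimated range from 60000 nM to 320000 nM for a single measurement.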

Compound 3, half-maximal cytotoxic concentration: 127000 nM
Beside the measured number, compound 3's estimate is 1.2-fold (0.07 log units) above it; the range from low to high includes it.
By their numbers in this assay, from the lowest: compounds 3, 2 and 1 (each within the scatter of the next).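

In this assay, among these compounds, phenyl in place of 3-bromo-5-methylpyridin-2-yl on an amide-type nitrogen gives a 1.1-fold lower number from compound 2 to compound 3 (0.05 log units; within the scatter) and provides the first comparison that differs in only one place. At this position, the aromatic group can therefore lose its bromine, its methyl and its ring nitrogen in a single exchange, going from 8 heavy atoms to 6, without the number leaving the scatter, although this one step cannot show what each of those features contributes alone. Nothing measured here offers an explanation for this result.

From the compounds shown here alone, it remains open whether this insensitivity extends beyond these two aromatic groups, for example to a phenyl carrying a carboxylic acid or an amine, or to a saturated alkyl chain on the same amide-type nitrogen. Going by these compounds, it also remains open whether the read-out would respond to a change elsewhere on the shared core, such as replacing the thioether-linked acetamide chain with a longer chain, since the present single-place comparison covers only the group on that nitrogen.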